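Bromine for chlorine on the cinnamate ester

The source may report more compounds than this note shows. Statements on the series, on what has been measured and on what is new or still open speak of the compounds shown alone.

Three esters of a shared core have been measured in a functional assay, read by spectrophotometry, with a stated time of 30 min; a higher number here means that more compound is needed for the effect, a lower number that less compound is needed. Compound 1 `COc1cc(C2Oc3cc([C@H]4Oc5cc(O)cc(O)c5C(=O)[C@@H]4O)ccc3OC2COC(=O)c2ccc(N)cc2)ccc1O` gives 128000 nM. Compound 2 `COc1cc(C2Oc3cc([C@H]4Oc5cc(O)cc(O)c5C(=O)[C@@H]4O)ccc3OC2COC(=O)c2ccccc2)ccc1O` gives 105000 nM, and the step of a 1.2-fold lower number from compound 1 to compound 2 (0.09 log units; within the scatter) shows how little the amino group contributes. Compound 3 `COc1cc(C2Oc3cc([C@H]4Oc5cc(O)cc(O)c5C(=O)[C@@H]4O)ccc3OC2COC(=O)/C=C/c2ccc(Cl)cc2)ccc1O`, carrying the 2-(4-chlorophenyl)ethenyl group on the carbonyl carbon, gives 87900 nM; the steps of a 1.5-fold lower number from compound 1 to compound 3 (0.16 log units; within the scatter) and a 1.2-fold lower number from compound 2 to compound 3 (0.08 log units; within the scatter) place it at the low end of the three numbers, though none of these differences rises above the scatter, so no order among the three can be claimed.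

Compound 4 `COc1cc(C2Oc3cc([C@H]4Oc5cc(O)cc(O)c5C(=O)[C@@H]4O)ccc3OC2COC(=O)/C=C/c2ccc(Br)cc2)ccc1O` differs from compound 3 by bromo in place of chloro on an aromatic carbon. Within the data shown here, no measured step exchanges one halogen for another, so the expectation rests on the general pattern of the series: the ester substituent was varied widely from compound 1 through compound 3 and the number hardly moved. A swap of bromo for chloro is a smaller change than any of those. Compound 4 is therefore expected to give 80000 nM, with a plausible range of 40000 nM to 160000 nM, and the estimated step of a 1.1-fold lower number from compound 3 to compound 4 (0.04 log units; within the scatter) is expected to stay within the scatter.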

Compound 4, half-maximal effective concentration: 88900 nM
The estimate for compound 4 lay 1.1-fold (0.05 log units) below the measured number; the measured number falls inside the stated range.
By their numbers in this assay, from the lowest: compounds 3, 4, 2 and 1 (each within the scatter of the next).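

In this assay, among these compounds, bromo in place of chloro on an aromatic carbon, para to a large group, gives the first direct reading of a change at this position (a 1.0-fold higher number from compound 3 to compound 4 (0.00 log units; within the scatter)), and the two halogens cannot be told apart there. The 2-(4-bromophenyl)ethenyl group is also not separated from the simpler esters, whether phenyl (a 1.2-fold lower number from compound 2 to compound 4 (0.07 log units; within the scatter)) or 4-aminophenyl (a 1.4-fold lower number from compound 1 to compound 4 (0.16 log units; within the scatter)) is the group it replaces on the carbonyl carbon, so it behaves here as the 2-(4-chlorophenyl)ethenyl group did in compound 3. Nothing available explains why the number holds steady across this exchange.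

The compounds shown leave open whether a group of another kind at this same position, such as a nitro group, a methoxy group or a carboxylic acid, would produce a step beyond the scatter. They also leave open whether anything other than the ester substituent matters, for instance a longer chain between the carbonyl carbon and the aromatic ring, or a change on the shared core itself.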